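The source may report more compounds than this note shows. Statements on the series, on what has been measured and on what is new or still open speak of the compounds shown alone.

Compound 1 `N#CC1=C(N)Oc2c(N)cc3nc4ccccc4nc3c2C12C(=O)N(Cc1cnnn1-c1cccc(C(F)(F)F)c1)c1ccccc12` gives 18900 nM in a functional assay on HCT-116 cells (Homo sapiens) for antiproliferative activity, read by MTT assay, with a stated time of 48 h; a lower number here means a stronger inhibitor, a higher number a weaker inhibitor. As far as these compounds go, compound 2 `Cc1ccc(-n2nncc2CN2C(=O)C3(C(C#N)=C(N)Oc4c(N)cc5nc6ccccc6nc5c43)c3ccccc32)cc1Cl` reaches only a limit of this assay, > 50000 nM, so where it truly stands is unknown beyond that limit. Among the measured compounds shown here, the single measured step, an at least 2.6-fold higher number from compound 1 to compound 2 (0.42 log units; beyond the scatter), rests on a value that sits at the limit of > 50000 nM in this assay, at which 1 of the 2 values shown sits, so its full size is not known. Compound 3 `N#CC1=C(N)Oc2c(N)cc3nc4ccccc4nc3c2C12C(=O)N(Cc1cnnn1-c1ccc(F)c(Cl)c1)c1ccccc12` differs from compound 2 by fluoro in place of methyl on an aromatic carbon. For the measured compounds named here, no measured step covers this change, and the one step known ended at a limit, so a small step is expected, an at least 1.1-fold lower number from compound 2 to compound 3 (0.04 log units; that floor lies within the scatter). Compound 3 is expected to give about 45000 nM in this assay, between 15000 nM and 150000 nM.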

Compound 3, half-maximal inhibitory concentration: > 50000 nM
Compound 3: no number, only a limit (the forecaster's own chance of this, stated with the estimate: 55%); at least 1.1-fold (0.04 log units) between middle value and limit.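

The change to 3-chloro-4-fluorophenyl in place of 3-(trifluoromethyl)phenyl gives an at least 2.6-fold higher number from compound 1 to compound 3 (0.42 log units; beyond the scatter) in this assay. The loss seen with the 3-chloro-4-methylphenyl ring therefore appears with fluoro in place of methyl too, and compound 1 remains the only one of the three with a number. The step between compound 2 and compound 3 cannot be read, as both values are limits: the limit of > 50000 nM in this assay, at which 2 of the 3 values shown sit.

Still open, as far as these compounds go, is how far beyond that limit compound 2 and compound 3 truly stand. From the compounds shown here alone, it is also open whether an amine or a carboxylic acid in place of the fluoro would bring a number back.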